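Piperidine amine variation in a tryptamine-triazole series

A few compounds are considered here, and "the series" means these few. Any claim that something is new, unique, unknown or untested is made for them only; others in the source may bear on it.

Measured so far in an assay on CHO cells for displacement of a labelled ligand from 5-hydroxytryptamine receptor 1D (Homo sapiens); on this read-out lower numbers stand for stronger inhibition and higher numbers for weaker inhibition:
Compound 1 `C[C@@H](NCC1CCN(CCCc2c[nH]c3ccc(-n4cnnc4)cc23)CC1)c1ccccc1`: 1.4 nM
Compound 2 `O[C@@H]1Cc2ccccc2[C@H]1NC1CCN(CCCc2c[nH]c3ccc(-n4cnnc4)cc23)CC1`: 6.6 nM
Compound 3 `CC(=O)Nc1ccc(CNC2CCN(CCCc3c[nH]c4ccc(-n5cnnc5)cc34)CC2)cc1`: 3 nM

Compound 2 gives the highest of the three numbers; the steps of a 4.7-fold higher number from compound 1 to compound 2 (0.67 log units; beyond the scatter) and a 2.2-fold lower number from compound 2 to compound 3 (0.34 log units; beyond the scatter) both lie beyond the scatter, so compound 2 is the weakest of the measured set. Compound 4 `CN(Cc1ccsc1)C1CCN(CCCc2c[nH]c3ccc(-n4cnnc4)cc23)CC1` is not yet measured. It differs from compound 2 in one place: methyl((thiophen-3-yl)methyl)amino in place of (2-hydroxy-2,3-dihydro-1H-inden-1-yl)amino on a saturated ring carbon. Going by the values given here, two measured steps bear on this. Exchanging the same group of compound 2 for 4-acetamidobenzyl lowered the number, a 2.2-fold lower number from compound 2 to compound 3 (0.34 log units; beyond the scatter), and the step of a 4.7-fold higher number from compound 1 to compound 2 (0.67 log units; beyond the scatter) shows that the group carried by compound 2 goes with the highest number of the set. Among the compounds with values here, no measured compound carries a methyl on the amine nitrogen or a thiophene ring, so the size of the step is uncertain. A modest step down in this assay is expected, a 2.2-fold lower number from compound 2 to compound 4 (0.34 log units; beyond the scatter). For compound 4 the estimate in this assay is 3 nM, with a range from 1 nM to 9 nM.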

Compound 4, half-maximal inhibitory concentration: 1.5 nM
For compound 4 the middle estimate is 2.0-fold (0.30 log units) above the measured one; the measured number falls inside the stated range.
By their numbers in this assay, from the lowest: compounds 1, 4 and 3 (each within the scatter of the next, the first and the last beyond it); then compound 2.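

In this assay, methyl((thiophen-3-yl)methyl)amino in place of (2-hydroxy-2,3-dihydro-1H-inden-1-yl)amino gives a 4.4-fold lower number from compound 2 to compound 4 (0.64 log units; beyond the scatter), and the entering group has 0 hydrogen-bond donors and no six-membered aromatic ring of carbon only, so neither feature of the leaving group is needed on this saturated ring carbon for a low number. The step of a 1.1-fold higher number from compound 1 to compound 4 (0.03 log units; within the scatter) lies within the scatter, so methyl((thiophen-3-yl)methyl)amino and ((1-phenylethyl)amino)methyl cannot be told apart at this position. No available data account for either step.

The change swaps several features at once, so the shares of the amine methyl, the thiophene and the lost hydroxyl remain unseparated. Also open, as far as these compounds go, is how the unmethylated (thiophen-3-yl)methylamino group or a methyl(benzyl)amino group would read at this position.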